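Methoxy for fluoro in compound 1: outlook for compound 3

The source may hold more compounds than are shown below. What is called first, only, known or untested is meant among the compounds shown, and "the series" means these compounds.

Compound 1 `O=C(/C=C\Nc1ccc(C(F)(F)F)cc1)c1cn(-c2ccccc2)nc1-c1ccc(F)cc1` and compound 2 `O=C(/C=C\Nc1ccc(O)cc1)c1cn(-c2ccccc2)nc1-c1ccc(F)cc1` share one core and differ in a single group. In an ADME assay on HaCaT cells (Homo sapiens) for antiproliferative activity, read by MTT assay, with a stated time of 48 h (a higher number here means a weaker inhibitor, a lower number a stronger inhibitor), compound 1 gives only a limit, > 50000 nM. In this assay compound 2 gives 16300 nM. The step of an at least 3.0-fold lower number from compound 1 to compound 2 (0.48 log units; beyond the scatter) is therefore known only as a lower bound because compound 1 sits at the limit of > 50000 nM in this assay, at which 1 of the 2 values shown sits.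

Compound 3 `COc1ccc(-c2nn(-c3ccccc3)cc2C(=O)/C=C\Nc2ccc(C(F)(F)F)cc2)cc1` has not yet been measured in this assay. It differs from compound 1 as follows: methoxy in place of fluoro on an aromatic carbon. For the measured compounds named here, the one measured step, an at least 3.0-fold lower number from compound 1 to compound 2 (0.48 log units; beyond the scatter), concerns hydroxy in place of trifluoromethyl, a different group, so it does not bear on the fluoro-to-methoxy change, and no other measured step does. Going by the values given here, with compound 1 standing at a limit and no step to draw on, the expected step that the limit leaves unreadable from compound 1 to compound 3 is none beyond the scatter. The estimate for compound 3 in this assay is 60000 nM, with a range from 20000 nM to 200000 nM, and a real chance that only a limit is reported again.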

Compound 3, half-maximal inhibitory concentration: > 50000 nM
Compound 3 ended at the assay's limit; the forecaster's own chance of this, stated with the estimate: 60%; the middle value does not contradict the limit.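

No step from compound 1 to compound 3 can be read in this assay because both compounds stand at a limit: the limit of > 50000 nM in this assay, at which 2 of the 3 values shown sit.

The compounds shown leave open whether 4-methoxyphenyl in place of 4-fluorophenyl changes the read-out at all; of the three, only compound 2 gives a number, 16300 nM.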